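The compounds below may be only part of what the source reports. "The series", "measured", "known", "first", "only" and "open" are said of these compounds alone.

Among the measured compounds shown here, compound 2 `COc1cc(/C=C/c2nc(Nc3ccc(C(C)C)cc3)c3sccc3n2)cc(OC)c1OC` is the only compound here with a numerical result in a functional assay on L02 cells (Homo sapiens) for inhibition, read by Griess assay, with stated times of 1 h and 24 h; a lower number here means a stronger inhibitor, a higher number a weaker inhibitor: in that assay compound 2 gives 370000 nM, so it stands as the sole measured point, with nothing to rank it against. Compound 1 `CNc1nc(/C=C/c2ccccc2)nc2ccsc12` gives no number in this assay but only a limit, > 1000000 nM. That value sits at the limit of > 1000000 nM in this assay, at which 1 of the 2 values shown sits.

Compound 3 `COc1cc(/C=C/c2nc(NCc3ccco3)c3sccc3n2)cc(OC)c1OC` has not yet been measured in this assay. It differs from compound 2 in one place: (furan-2-yl)methyl in place of 4-isopropylphenyl on a nitrogen on an aromatic ring. The group that leaves is 4-isopropylphenyl, the group that enters is (furan-2-yl)methyl, and the place is a nitrogen on an aromatic ring whose other neighbours are aromatic carbon.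

For the measured compounds named here, no step between two measured compounds is available, so the effect of this change on potency cannot be read from the data. The expected step is a 1.1-fold higher number from compound 2 to compound 3 (0.03 log units; within the scatter), which is no more than the usual scatter in either direction. In this assay compound 3 is therefore estimated to give about 400000 nM, with a likely range from 100000 nM to 1000000 nM.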

Compound 3, half-maximal inhibitory concentration: 189000 nM
Beside the measured number, compound 3's estimate is 2.1-fold (0.33 log units) above it; low and high end bracket the measured number.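

In this assay, among the compounds shown here, this is the first step that can be read at this nitrogen on an aromatic ring: (furan-2-yl)methyl in place of 4-isopropylphenyl gives a 2.0-fold lower number from compound 2 to compound 3 (0.29 log units; within the scatter). A six-membered aromatic ring of carbon only and a five-membered aromatic ring with a hetero atom, the latter carrying a methylene link to the nitrogen, therefore cannot be told apart by this measurement, and the pair shows that this particular change does not move the number beyond what repeated measurements would. Nothing measured here accounts for the size of the step, so no cause can be given for it.

The compounds shown leave open whether a group of a different kind on this nitrogen, such as a carboxylic acid or a longer chain ending in an amine, would shift the number beyond the scatter. Compound 1 gives only a limit of the assay, > 1000000 nM, and it differs from the others in more than one place, so what the rest of the molecule contributes also stays unresolved.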